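Notes on a 2,4-dimethoxyphenyl replacement in the series

A few compounds are considered here, and "the series" means these few. Any claim that something is new, unique, unknown or untested is made for them only; others in the source may bear on it.

In a functional assay on HL-60 cells (Homo sapiens) for antiproliferative activity, with a stated time of 72 h (a higher number here means a weaker inhibitor, a lower number a stronger inhibitor), compound 1 `OC[C@H]1O[C@@H](n2cnc3c(NCc4cccc(Br)c4)ncnc32)[C@H](O)[C@@H]1O` gives 8000 nM and compound 2 `Cc1cccc(CNc2ncnc3c2ncn3[C@@H]2O[C@H](CO)[C@@H](O)[C@H]2O)c1` gives 6400 nM. Among the compounds with values here, these two numbers lie within the scatter of each other, so compound 2 stands level with its only measured neighbour. The next structure, compound 3 `COc1ccc(CNc2ncnc3c2ncn3[C@@H]2O[C@H](CO)[C@@H](O)[C@H]2O)c(OC)c1`, carries 2,4-dimethoxyphenyl in place of 3-methylphenyl on a saturated chain carbon bound to a nitrogen on an aromatic ring. Within the data shown here, the only measured step is a 1.3-fold lower number from compound 1 to compound 2 (0.10 log units; within the scatter), methyl in place of bromo on an aromatic carbon, and it stays within the scatter. Among the measured compounds shown here, no measured compound carries a dimethoxyphenyl group, so that step offers limited guidance. No shift beyond the scatter is expected in this assay, in either direction. The expected step is a 1.1-fold lower number from compound 2 to compound 3 (0.03 log units; within the scatter). The estimated value for compound 3 is 6000 nM, with an expected range of 2000 nM to 18000 nM.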

Compound 3, half-maximal inhibitory concentration: 39000 nM
For compound 3 the middle estimate is 6.5-fold (0.81 log units) below the measured one; the whole stated range lies below it.
By their numbers in this assay, from the lowest: compounds 2 and 1 (each within the scatter of the next); then compound 3.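

In this assay, the position on a saturated chain carbon bound to a nitrogen on an aromatic ring now shows its first change beyond the scatter: 2,4-dimethoxyphenyl in place of 3-methylphenyl gives a 6.1-fold higher number from compound 2 to compound 3 (0.78 log units; beyond the scatter), and 2,4-dimethoxyphenyl in place of 3-bromophenyl gives a 4.9-fold higher number from compound 1 to compound 3 (0.69 log units; beyond the scatter). Compound 1 and compound 2 stand level, so the aromatic group at this position is not interchangeable, and both new steps run towards a weaker inhibitor. Nothing available explains this shift.

The compounds shown do not separate the contributions of the two methoxy groups, so it remains open whether a single methoxy group would give a similar step. Also open, on these data alone, is how a phenyl ring carrying an amine or a carboxylic acid would read at this position.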